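This account rests on a few compounds, and the source may have more. Where it says the series, first, only, none or still open, it means among the compounds named here.

Three measured compounds share a core in which a ring-bound amide-type nitrogen carries an acyl group. Compound 1 `O=C(C1CCC1)N1CCCC[C@H]1c1nc(-c2cccc(F)c2)no1` and compound 2 `O=C(C1CCC1)N1CCC[C@@H]1c1nc(-c2cccc(F)c2)no1` both bear a cyclobutyl group on the carbonyl carbon; in an in vitro functional assay on HEK293-A cells for positive allosteric modulation of metabotropic glutamate receptor 5 (Homo sapiens), read by fluorescence and calcium flux, with a stated time of 140 s (a higher number here means that more compound is needed for the effect, a lower number that less compound is needed), compound 1 gives 700 nM and compound 2 gives 530 nM, two numbers that lie within the usual scatter of each other. Compound 3 `O=C(C1CC1)N1CCCC1c1nc(-c2cccc(F)c2)no1` carries a cyclopropyl group on the carbonyl carbon instead, and in this assay compound 3 gives 2900 nM, the highest of the three numbers, with its gap to compound 1 and to compound 2 each beyond the scatter.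

Compound 4 `O=C(c1ccc(F)c(F)c1)N1CCCC1c1nc(-c2cccc(F)c2)no1` differs from compound 3 in one place: 3,4-difluorophenyl in place of cyclopropyl on a carbonyl carbon. Within the data shown here, no measured pair shows this exchange, so its effect is not known from these data. Since every acyl group measured so far is a small saturated ring and the aromatic ring with two fluorines is new to the set, the outcome is uncertain; the step of a 2.9-fold lower number from compound 3 to compound 4 (0.46 log units; beyond the scatter) is expected to be a modest move toward a lower number, possibly no further than the scatter. Compound 4 is therefore estimated at 1000 nM, within a range from 300 nM to 3500 nM.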

Compound 4, half-maximal effective concentration: 3700 nM
The estimate for compound 4 lay 3.7-fold (0.57 log units) below the measured number; the whole stated range lies below it.
By their numbers in this assay, from the lowest: compounds 2 and 1 (each within the scatter of the next); then compounds 3 and 4 (each within the scatter of the next).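

In this assay, among these compounds, 3,4-difluorophenyl in place of cyclopropyl on a carbonyl carbon gives a 1.3-fold higher number from compound 3 to compound 4 (0.11 log units; within the scatter), the first reading in this set of a change made in one place only. At this position, on a carbonyl carbon whose other neighbour is an amide-type nitrogen in a ring, a saturated ring with 3 heavy atoms and an aromatic ring with 8 heavy atoms, two of them fluorine, cannot be told apart in this assay, so the acyl group here is not limited to a small saturated ring. Nothing measured on these compounds accounts for this outcome.

As far as these compounds go, whether a phenyl without fluorine, an acyl group bearing an amine or a carboxylic acid, or a longer chain on this carbonyl carbon would shift the number beyond the scatter remains open. From the compounds shown here alone, it also remains open whether 3,4-difluorophenyl would read the same way in place of the cyclobutyl group on the cores of compound 1 and compound 2.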